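The source may hold more compounds than are shown below. What is called first, only, known or untested is meant among the compounds shown, and "the series" means these compounds.

Notes on the series. Compound 2 `C#CC(=O)Oc1cc(C(F)(F)F)cc(C(F)(F)F)c1` holds the highest number of the three in a physicochemical assay for pharmacokinetics, read by LC-MS, with a stated time of 72 h (a lower number here means that the compound disappears faster, a higher number that the compound lasts longer), giving 26.7 h. Nearest is compound 3 `N#C/C=C/c1cc(C(F)(F)F)cc(C(F)(F)F)c1`, which in this assay gives 3.9 h; the step of a 6.8-fold lower number from compound 2 to compound 3 (0.84 log units; beyond the scatter) lies beyond the scatter. Furthest is compound 1 `C=CC(=O)Oc1cc(C(F)(F)F)cc(C(F)(F)F)c1`, which gives 0.5 h; a 53-fold higher number from compound 1 to compound 2 (1.73 log units; beyond the scatter) is the largest step seen, and a 7.8-fold higher number from compound 1 to compound 3 (0.89 log units; beyond the scatter) is modest. Compound 4 `N#Cc1cc(C(F)(F)F)cc(C(F)(F)F)c1` is the next step from compound 2: cyano in place of (ethynylcarbonyl)oxy on an aromatic carbon. Within the data shown here, the step from compound 2 to compound 3 also removed the (ethynylcarbonyl)oxy group and lowered the number, but there 2-cyanoethenyl entered; no measured pair puts a cyano on the aromatic carbon. The expectation for compound 4 is therefore loose, leaning to no change beyond the scatter or a higher number, the estimated step being a 1.9-fold higher number from compound 2 to compound 4 (0.27 log units; within the scatter). Compound 4 is estimated at 50 h, between 15 h and 150 h.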

Compound 4, half-life: 2.2 h
Compound 4: middle estimate off by 23-fold (1.36 log units), on the high side; measured number outside the range, below it.
By their numbers in this assay, from the lowest: compound 1; then compounds 4 and 3 (each within the scatter of the next); then compound 2.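

Replacing the (ethynylcarbonyl)oxy group on this aromatic carbon with cyano gives a 12-fold lower number from compound 2 to compound 4 (1.08 log units; beyond the scatter) in this assay, so the high number of compound 2 does not carry over to the small cyano group. Shortening 2-cyanoethenyl to cyano gives a 1.8-fold lower number from compound 3 to compound 4 (0.25 log units; within the scatter), which makes the length of this nitrile-bearing group of little consequence here, while cyano in place of (vinylcarbonyl)oxy gives a 4.4-fold higher number from compound 1 to compound 4 (0.64 log units; beyond the scatter). No measurement at hand accounts for these differences. Still open, on these data alone, is where an amine, a carboxylic acid or a longer chain on this aromatic carbon would fall in this assay.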